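Swapping a methyl for a bromine on a hanging phenyl ring

This account rests on a few compounds, and the source may have more. Where it says the series, first, only, none or still open, it means among the compounds named here.

Of the compounds shown here, two with a shared core have been measured so far. Compound 1 `C#CCNC1CCc2c(SCc3ccc(Br)cc3)cccc21` carries a 4-bromophenyl attached directly to the carbon next to sulfur; in an ADME assay on isolated protein for inhibition of Amine oxidase [flavin-containing] B (Homo sapiens) (a lower number here means a stronger inhibitor, a higher number a weaker inhibitor), compound 1 gives 488 nM. Compound 2 `C#CCNC1CCc2c(SCCc3ccc(C)cc3)cccc21` has a longer two-carbon chain ending in a 4-methylphenyl; in this assay compound 2 gives 4520 nM, the highest of the two numbers and beyond the scatter from compound 1.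

Compound 3 `C#CCNC1CCc2c(SCCc3cccc(Br)c3)cccc21` keeps the two-carbon chain of compound 2 and changes only the ring at its end: 3-bromophenyl in place of 4-methylphenyl on a saturated chain carbon, two bonds along the chain from a sulfur. Among the measured compounds shown here, no pair of measured compounds shows this exact swap, so its effect is unknown. Compound 1 shows that a bromine on the hanging ring goes together with a low number, but that compound also differs in chain length, so it gives no clean guide. A modest move toward a lower number seems the most reasonable expectation for compound 3, with wide uncertainty.

For compound 3 in this assay the expected value is 2500 nM, within a range of 700 nM to 9000 nM, which corresponds to an expected step of a 1.8-fold lower number from compound 2 to compound 3 (0.26 log units; within the scatter).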

Compound 3, half-maximal inhibitory concentration: 620 nM
For compound 3 the middle estimate is 4.0-fold (0.61 log units) above the measured one, and the stated range ends above it.
By their numbers in this assay, from the lowest: compounds 1 and 3 (each within the scatter of the next); then compound 2.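

Among the compounds shown here, with the chain held the same, compound 2 and compound 3 give the first clean reading of the ring at its end: in this assay, 3-bromophenyl in place of 4-methylphenyl gives a 7.3-fold lower number from compound 2 to compound 3 (0.86 log units; beyond the scatter). The two rings have the same heavy-atom count, and neither has a hydrogen-bond donor, a hydrogen-bond acceptor or a net charge, yet this change on a saturated chain carbon, two bonds along the chain from a sulfur, still gives a step beyond the scatter, so those counts alone do not settle the result here. No measured information on the compounds accounts for the size of this step.

The swap changes two things at once, the kind of group on the ring and where it sits, and these two compounds cannot separate them. A 3-methylphenyl at the end of the same chain would isolate the effect of the group, while a plain phenyl would show whether the methyl of compound 2 or the bromine of compound 3 accounts for more of the step.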